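This account rests on a few compounds, and the source may have more. Where it says the series, first, only, none or still open, it means among the compounds named here.

Measured in a functional assay on HL-60 cells (Homo sapiens) for cytotoxicity, read by luminescence and CellTiter-Glo, with a stated time of 3 days; on this read-out higher numbers stand for weaker inhibition and lower numbers for stronger inhibition:
- compound 1 `N#Cc1ccc(NC(=O)c2cc(-c3ccccc3)ccc2O)cc1`: 1350 nM
- compound 2 `N#Cc1ccc(NC(=O)c2cc(F)ccc2O)cc1`: 1420 nM
- compound 3 `N#Cc1ccc(NC(=O)c2cc(C(F)(F)F)ccc2O)cc1`: 3120 nM

Compound 3 has the highest number of the three, the weakest inhibition here. The steps to it are modest: a 2.2-fold higher number from compound 2 to compound 3 (0.34 log units; beyond the scatter) and a 2.3-fold higher number from compound 1 to compound 3 (0.36 log units; beyond the scatter).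

Next is compound 4 `N#Cc1ccc(NC(=O)c2cc(Br)ccc2O)cc1`: bromo in place of trifluoromethyl on an aromatic carbon. The new bromo stays para to a hydroxy group. For the measured compounds named here, no bromo compound has been measured. Fluoro and phenyl differ little, a 1.1-fold higher number from compound 1 to compound 2 (0.02 log units; within the scatter), and only trifluoromethyl stands apart. Bromo is therefore expected to fall nearer compound 1 and compound 2, giving a lower number in this assay, with a step about as large as those modest ones or smaller. The expected step is a 1.8-fold lower number from compound 3 to compound 4 (0.26 log units; within the scatter). Compound 4 is estimated at 1700 nM, with an expected range of 900 nM to 3300 nM.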

Compound 4, half-maximal inhibitory concentration: 620 nM
Compound 4: the middle estimate sits 2.7-fold (0.44 log units) above what was measured; measured number outside the range, below it.
By their numbers in this assay, from the lowest: compound 4; then compounds 1 and 2 (each within the scatter of the next); then compound 3.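

Bromo, para to a hydroxy group, is the first group at this position to stand clearly on the low side in this assay with a 2.3-fold lower number from compound 2 to compound 4 (0.36 log units; beyond the scatter) and a 2.2-fold lower number from compound 1 to compound 4 (0.34 log units; beyond the scatter) while fluoro and phenyl show no separation from each other. For the compounds shown here, the change from trifluoromethyl gives a 5.0-fold lower number from compound 3 to compound 4 (0.70 log units; beyond the scatter) and is the largest step, so this position separates its groups more widely than the earlier compounds showed. Nothing measured here accounts for the result with bromo.

As far as these compounds go, whether chloro or iodo at this position would track bromo remains open, as does how an amine or a methoxy group would compare. Also open, from the compounds shown here alone, is whether the bromo result holds with another group in place of the nitrile.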